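From compound 3 to compound 4: a permeability estimate

The source may report more compounds than this note shows. Statements on the series, on what has been measured and on what is new or still open speak of the compounds shown alone.

Measured compounds in an ADME assay on MDCK cells (Canis lupus familiaris) for permeability, read by LC-MS, with a stated time of 90 min, tested at 2 uM (a higher number here means that the compound crosses the layer faster, a lower number that the compound crosses the layer more slowly), so far:
- compound 1 (`COC(c1cc(Cl)c2c(c1Cl)C(=O)N(Cc1c(C)cc(C)[nH]c1=O)CC2)C1CCOCC1`) gives 13.3 10^-6 cm/s; 16.5 10^-6 cm/s (2 entries) in two entries
- compound 2 (`COC(c1cc(Cl)c2c(c1Cl)C(=O)N(Cc1c(C)cc(C)[nH]c1=O)CC2)C1CCS(=O)(=O)CC1`) gives 6.3 10^-6 cm/s; 5.7 10^-6 cm/s (2 entries) in two entries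
- compound 3 (`Cc1cc(C)c(CN2CCc3c(Cl)cc([C@H](CO)[C@@H]4CCCO4)c(Cl)c3C2=O)c(=O)[nH]1`) gives 14.6 10^-6 cm/s in one entry

Going by the values given here, compound 3 has 14.6 10^-6 cm/s as its only number in this assay and two further entries for it gave no single number. Compound 4 (`Cc1cc(C)c(CN2CCc3c(Cl)cc(-c4c(C)noc4C)c(Cl)c3C2=O)c(=O)[nH]1`) differs from compound 3 on an aromatic carbon of the shared core: a group of 7 heavy atoms (5 carbon, 1 nitrogen, 1 oxygen; one five-membered aromatic ring with 2 hetero atoms) in place of a group of 8 heavy atoms (6 carbon, 2 oxygen; one five-membered non-aromatic ring with 1 hetero atom), on an aromatic carbon is the whole change. Among the compounds with values here, no measured step covers this change, so with compound 3 at 14.6 10^-6 cm/s as the starting point, no shift beyond the scatter is expected. The estimate is a 1.2-fold higher number from compound 3 to compound 4 (0.09 log units; within the scatter) as the expected step. Compound 4 is estimated at 18 10^-6 cm/s with 9 10^-6 cm/s to 32 10^-6 cm/s as its expected range.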

Compound 4, apparent permeability: 15.7 10^-6 cm/s
For compound 4 the middle estimate is 1.1-fold (0.06 log units) above the measured one; the range from low to high includes it.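

On this aromatic carbon, ortho to a chloro group, 3,5-dimethyl-1,2-oxazol-4-yl replaces a non-aromatic ring-bearing group with two defined stereocentres, and the result in this assay is a 1.1-fold higher number from compound 3 to compound 4 (0.03 log units; within the scatter). The group that leaves carries a hydrogen-bond donor and the group that enters carries none, yet the step stays within the scatter. It is no larger than the spread among repeat entries: the several entries of compound 1 in this assay, 13.3 10^-6 cm/s; 16.5 10^-6 cm/s (2 entries)

The compounds shown leave open how an amine or a carboxylic acid on this aromatic carbon would read in this assay.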